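From 3,5-dichlorophenyl to 3,5-dimethoxyphenyl: notes on compound 3

The compounds below may be only part of what the source reports. "The series", "measured", "known", "first", "only" and "open" are said of these compounds alone.

Of the compounds shown here, two have numbers so far. In a functional assay on A549 cells (Homo sapiens) for inhibition, read by MTT assay, with a stated time of 72 h (a lower number here means a stronger inhibitor, a higher number a weaker inhibitor), compound 1 (`COc1cc(OC)cc(N2CCN(C(=O)c3oc(C)nc3-c3ccccc3F)CC2)c1`) gives 27 nM, and compound 2 (`Cc1nc(-c2cccc(F)c2)c(C(=O)N2CCN(c3cc(Cl)cc(Cl)c3)CC2)o1`) gives 354 nM. Compound 2 therefore holds the higher of the two numbers, with a gap to compound 1 beyond the scatter. The two differ in more than one place, so no single change has a measured size yet.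

Compound 3 (`COc1cc(OC)cc(N2CCN(C(=O)c3oc(C)nc3-c3cccc(F)c3)CC2)c1`) departs from compound 2 at one place: 3,5-dimethoxyphenyl in place of 3,5-dichlorophenyl on an amine nitrogen in a ring, with 3,5-dimethoxyphenyl in place of 3,5-dichlorophenyl on an amine nitrogen in a ring. The 3,5-dimethoxyphenyl group also occurs in compound 1, at 27 nM, and this single value is the only support for the expected direction. The expected change is a 5.1-fold lower number from compound 2 to compound 3 (0.70 log units; beyond the scatter), a drop beyond the scatter in this assay. The estimate for compound 3 is 70 nM, with an expected range of 20 nM to 250 nM.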

Compound 3, half-maximal inhibitory concentration: 98 nM
Estimate against measurement, compound 3: 1.4-fold (0.15 log units) below; the range from low to high includes it.
By their numbers in this assay, from the lowest: compound 1; then compound 3; then compound 2.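

In this assay, 3,5-dimethoxyphenyl in place of 3,5-dichlorophenyl on an amine nitrogen in a ring gives a 3.6-fold lower number from compound 2 to compound 3 (0.56 log units; beyond the scatter), the first measured size for this change, read with 3-fluorophenyl held constant. The fluorophenyl position now has a size too: 3-fluorophenyl in place of 2-fluorophenyl on an aromatic carbon, with 3,5-dimethoxyphenyl held constant, gives a 3.6-fold higher number from compound 1 to compound 3 (0.56 log units; beyond the scatter), so both places carry a step beyond the scatter. Nothing on hand offers an explanation for either step.

Going by these compounds, each step is read on a single background, so whether the 3,5-dimethoxyphenyl step keeps its size alongside 2-fluorophenyl remains open. Also open is how a 3,5-dimethylphenyl group on that amine nitrogen would compare with the two groups shown.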